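Urea analogues on a shared quinoline-type core in L1210 cells

A few compounds are considered here, and "the series" means these few. Any claim that something is new, unique, unknown or untested is made for them only; others in the source may bear on it.

The measured compounds:
compound 1, `COc1cc(NC(C)CCCNC(=O)NNC(=O)Nc2cc(C(F)(F)F)cc(C(F)(F)F)c2)c2ncccc2c1`, 18000 nM
compound 2, `COc1cc(NC(C)CCCNC(=O)Nc2ccc(O)cc2)c2ncccc2c1`, 21000 nM
compound 3, `COc1cc(NC(C)CCCNC(=O)NNC(=O)Nc2ccc(C(F)(F)F)cc2)c2ncccc2c1`, 18000 nM

In a functional assay on L1210 cells (Mus musculus) for inhibition, read by MTT assay, with a stated time of 72 h (on this read-out higher numbers stand for weaker inhibition and lower numbers for stronger inhibition), compound 2 gives 21000 nM. Compound 1 gives 18000 nM and compound 3 gives 18000 nM in this assay, and the gaps from compound 2 to each of them lie within the usual scatter, so compound 2 stands level with the other two rather than apart from them.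

Compound 4, `COc1cc(NC(C)CCCNC(=O)Nc2cccc(Cl)c2)c2ncccc2c1`, has not yet been measured in this assay. It differs from compound 2 in one place: 3-chlorophenyl in place of 4-hydroxyphenyl on an amide-type nitrogen. Within the data shown here, no measured pair shows what this change does, so there is no step to lean on. The three values already at hand all sit close together despite different groups on the urea side of the molecule, and on that ground compound 4 is expected to land near compound 2, with the step from compound 2 to compound 4 estimated at a 1.2-fold lower number from compound 2 to compound 4 (0.07 log units; within the scatter), that is, none beyond the scatter. Compound 4 is therefore estimated at 18000 nM, within the range 7000 nM to 45000 nM.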

Compound 4, half-maximal inhibitory concentration: 17000 nM
Beside the measured number, compound 4's estimate is 1.1-fold (0.02 log units) above it; the measured number falls inside the stated range.
By their numbers in this assay, from the lowest: compounds 4, 1, 3 and 2 (each within the scatter of the next).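

In this assay, among these compounds, a 1.2-fold lower number from compound 2 to compound 4 (0.09 log units; within the scatter), which gives the first direct reading of a change on this amide-type nitrogen. Exchanging 4-hydroxyphenyl for 3-chlorophenyl removes the hydrogen-bond donor and acceptor of the group that leaves, and the entering group brings a chlorine, yet the two compounds stay level, so in this pair neither change moves the number beyond the scatter. Nothing at hand bears on why the number holds steady across this change.

The compounds shown leave open whether a different kind of group on this nitrogen, such as an aminophenyl, a carboxylic acid-bearing phenyl or a longer chain in place of the aromatic ring, would shift the number beyond the scatter. They also leave open whether any replacement here can separate itself from compound 2 in either direction.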